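The compounds below may be only part of what the source reports. "The series", "measured", "known", "first", "only" and "open" are said of these compounds alone.

Of the compounds shown here, three have been tested so far in an ADME assay on cells (Peritoneal macrophage cell, Mus musculus) for cytotoxicity; on this read-out higher numbers stand for weaker inhibition and lower numbers for stronger inhibition. Compound 1 `O=C(Cn1cnc([N+](=O)[O-])n1)Nc1ccc(Oc2ccc(F)cc2)cc1` gives a true number, 84000 nM. Compound 2 `O=C(Cn1ccnc1[N+](=O)[O-])Nc1ccc(Oc2ccccc2)cc1` gives only a limit, > 89000 nM. Compound 3 `O=C(Cn1ccnc1[N+](=O)[O-])Nc1ccc(Oc2ccc(Cl)cc2)cc1` also gives only a limit, > 81000 nM, so it has no exact place on the scale, and one other result shown is likewise a limit.

Compound 4 `O=C(Cn1ccnc1[N+](=O)[O-])Nc1ccc(Oc2ccc(F)cc2)cc1` keeps the structure of compound 3 except for one atom, with fluoro in place of chloro on an aromatic carbon, para to a large group (fluoro in place of chloro on an aromatic carbon). Among the compounds with values here, the only measured step at this place is a step that the two limits leave unreadable from compound 2 to compound 3, where chloro replaces hydrogen, so it offers no size to carry over. Within the data shown here, the sole guide to a number is compound 1, which also carries 4-fluorophenoxy but differs elsewhere in its structure, at 84000 nM. With neither hydrogen nor chloro at this place giving a number in this assay, no change beyond the scatter is expected, in either direction. The estimated step is a step that the limit leaves unreadable from compound 3 to compound 4, and this result may well arrive as a limit too. For compound 4 the expected value is 84000 nM, with an estimated range from 45000 nM to 130000 nM.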

Compound 4, half-maximal inhibitory concentration: > 84000 nM
Compound 4: no number, only a limit; the forecaster's own chance of this, stated with the estimate: 75%; the middle value sits exactly at the limit.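

In this assay compound 4 gives only a limit, > 84000 nM. With this result, hydrogen, chloro and fluoro on this aromatic carbon all end in limits, so the steps among compound 2, compound 3 and compound 4 cannot be read, and the change from chloro to fluoro has no size. Within the data shown here, the one reading lies at a different place, where 2-nitro-1H-imidazol-1-yl stands in place of 3-nitro-1H-1,2,4-triazol-1-yl: a number no lower from compound 1 to compound 4 (the limit leaves the size open).

As far as these compounds go, that reading gives a direction only, so how far compound 4 lies from compound 1 remains open, as does whether hydrogen, chloro and fluoro differ at all at this place. Also open, from the compounds shown here alone, is whether a methoxy group or an amine on this aromatic carbon would give a true number rather than another limit.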